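Series notes: piperidinyl replacement of a methoxyethylamino group

The compounds below may be only part of what the source reports. "The series", "measured", "known", "first", "only" and "open" are said of these compounds alone.

Of the compounds shown here, three of one core have been measured in an assay on isolated protein for inhibition of ribosomal protein S6 kinase alpha-5 (Homo sapiens), read by mobility shift assay, tested at 30 uM; a lower number here means less inhibition, a higher number more inhibition at the concentration tested (going by the name of the read-out). Compound 1 `COCCNc1nc(C)cc2nn(-c3ccccc3)c(N)c12` gives 3% in this assay. Compound 2 `Cc1cc2nn(-c3ccccc3)c(N)c2c(=O)[nH]1` gives 4% in this assay, and compound 3 `Nc1c2c(=O)[nH]c(-c3ccccn3)cc2nn1-c1ccccc1` gives 4% in this assay. For the measured compounds named here, compound 1 stands at the bottom of these three numbers, yet its gap to compound 2 and to compound 3 is within the scatter, so no compound is separated from another on these data. Going by the values given here, the only step between measured compounds that differ in one place, no change at the digits printed from compound 2 to compound 3 (within the scatter), is the pyridin-2-yl in place of methyl on an aromatic carbon, and it leaves the read-out where it was.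

Compound 4 `Cc1cc2nn(-c3ccccc3)c(N)c2c(N2CCCCC2)n1` has not been measured. It differs from compound 1 by piperidin-1-yl in place of (2-methoxyethyl)amino on an aromatic carbon. Among the compounds with values here, no measured step touches this position or these groups, so the measured step from compound 2 to compound 3 bears on it only indirectly, as a sign that this core sits near the floor of this assay regardless of substitution seen so far. The expected step of a number 2 percentage points higher from compound 1 to compound 4 (within the scatter) is therefore none beyond the scatter. For compound 4 the estimate in this assay is 5%, with a range from -5% to 18%.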

Compound 4, a percentage reported as inhibition, at one concentration (the size of the read-out at that concentration, not a potency): 10%
For compound 4 the middle estimate is 5 percentage points below the measured one; low and high end bracket the measured number.
By their numbers in this assay, from the lowest: compounds 1, 2, 3 and 4 (each within the scatter of the next).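

In this assay, for the compounds shown here, piperidin-1-yl in place of (2-methoxyethyl)amino gives a number 7 percentage points higher from compound 1 to compound 4 (within the scatter), the first measured step at this position, on an aromatic carbon next to the ring nitrogen. On this step, exchanging an open chain that carries a hydrogen-bond donor for a six-membered non-aromatic ring that carries none does not separate the two compounds at the concentration tested. No measurement at hand bears on why the step has this size.

The compounds shown leave open whether any other group at this position, such as morpholin-4-yl, a primary amine, a longer chain ending in a carboxylic acid or an aromatic ring, would move the read-out beyond the scatter of compound 1. Also open, on these data alone, is whether the same exchange would behave alike with pyridin-2-yl in place of the methyl group, and, since only inhibition at a single concentration is available, how these compounds would compare in potency.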